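Working notes: amino in place of hydroxy

The compounds below may be only part of what the source reports. "The series", "measured", "known", "first", "only" and "open" are said of these compounds alone.

Compound 1 `CCC(=O)N(c1ccc(Cl)c(Cl)c1)C1CCCC1O`: 0.4 mg/kg
Compound 2 `CCC(=O)N(c1cc(Cl)c(Cl)c(Cl)c1)C1CCCC1N(C)C`: 4 mg/kg

In a functional assay on the whole organism for positive allosteric modulation, with Mus musculus as the target (a lower number here means that less compound is needed, a higher number that more compound is needed for the effect), compound 1 gives 0.4 mg/kg, the lowest of the two numbers at hand. Compound 2 gives 4 mg/kg, a higher number beyond the scatter; these two compounds differ in more than one place, so the pair says nothing about any single change. Compound 3 `CCC(=O)N(c1ccc(Cl)c(Cl)c1)C1CCCC1N` is not yet measured. It differs from compound 1 by amino in place of hydroxy on a saturated ring carbon. Within the data shown here, no measured pair bears directly on this change, so only a small step is expected, with the number for compound 3 expected to move by a 2.0-fold higher number from compound 1 to compound 3 (0.30 log units; within the scatter). For compound 3 the estimate is 0.8 mg/kg, ranging from 0.2 mg/kg to 3 mg/kg.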

Compound 3, dose for half-maximal effect: 0.02 mg/kg
Estimate against measurement, compound 3: 40-fold (1.60 log units) above; the measured number lies below the stated range.
By their numbers in this assay, from the lowest: compound 3; then compound 1; then compound 2.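

In this assay, amino in place of hydroxy on a saturated ring carbon gives a 20-fold lower number from compound 1 to compound 3 (1.30 log units; beyond the scatter). This position, next to the ring atom that bears a large group, therefore responds strongly to this swap, although the counts of hydrogen-bond donors and acceptors stay the same. No measurement at hand speaks to the origin of the step.

Going by these compounds, compound 2 carries a dimethylamino group but differs from compound 3 in more than one place, so the effect of substitution on the nitrogen remains open. On these data alone, how a methylamino group or a carboxylic acid would fare at this position also remains open.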